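A few compounds are considered here, and "the series" means these few. Any claim that something is new, unique, unknown or untested is made for them only; others in the source may bear on it.

Of the compounds shown here, three sharing one core have been measured in a physicochemical assay for solubility, at pH 7.4; on this read-out lower numbers stand for lower solubility and higher numbers for higher solubility. Compound 1 `CN(C)C1(C)CN(c2c(F)cc3c(=O)c(C(=O)O)cn(C4CC4)c3c2F)C1` gives 23.6 ug/mL. Compound 2 `CC[C@H]1[C@@H](N)CN1c1c(F)cc2c(=O)c(C(=O)O)cn(C3CC3)c2c1F` gives 55.9 ug/mL, and compound 3 `CN[C@H]1CN(c2c(F)cc3c(=O)c(C(=O)O)cn(C4CC4)c3c2F)[C@@H]1C` gives 13.1 ug/mL. Among these three numbers compound 1 stands second highest; its nearest neighbour is compound 3, and the step of a 1.8-fold lower number from compound 1 to compound 3 (0.26 log units; within the scatter) lies within the scatter, whereas the step of a 2.4-fold higher number from compound 1 to compound 2 (0.37 log units; beyond the scatter) lies beyond it. The largest of the measured steps is a 4.3-fold lower number from compound 2 to compound 3 (0.63 log units; beyond the scatter).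

Compound 4 `C[C@@H]1[C@@H](N(C)C)CN1c1c(F)cc2c(=O)c(C(=O)O)cn(C3CC3)c2c1F` has not yet been measured. It differs from compound 1 in a single place: a group of 8 heavy atoms (6 carbon, 2 nitrogen; one four-membered non-aromatic ring with 1 hetero atom) in place of a group of 8 heavy atoms (6 carbon, 2 nitrogen; one four-membered non-aromatic ring with 1 hetero atom), on an aromatic carbon. The two compounds hold the same atoms, joined differently, so the change is one of arrangement rather than of size.

All three measured steps swap one azetidine-containing group for another on the same aromatic carbon, and none of them moved the number far: two were modest and one stayed within the scatter. Compound 3 carries a ring methyl and an amine much as compound 4 does, and the step of a 1.8-fold lower number from compound 1 to compound 3 (0.26 log units; within the scatter) stayed within the scatter, so a step of similar size is expected here. The value for compound 4 is expected to be 18 ug/mL, between 8 ug/mL and 45 ug/mL, an expected step of a 1.3-fold lower number from compound 1 to compound 4 (0.12 log units; within the scatter).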

Compound 4, solubility: 97.1 ug/mL
Compound 4: middle estimate off by 5.4-fold (0.73 log units), on the low side; measured number outside the range, above it.
By their numbers in this assay, from the lowest: compounds 3 and 1 (each within the scatter of the next); then compounds 2 and 4 (each within the scatter of the next).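

With the dimethylamino group kept and the atoms of the azetidine group only joined differently, the change from the 3-(dimethylamino)-3-methylazetidin-1-yl group to the group with two defined stereocentres gives a 4.1-fold higher number from compound 1 to compound 4 (0.61 log units; beyond the scatter) in this assay and so lies beyond the scatter, which shows that this position responds to arrangement even when the amine is left unchanged. The smallest change in the set, methyl in place of hydrogen on an amine nitrogen, gives a 7.4-fold higher number from compound 3 to compound 4 (0.87 log units; beyond the scatter) and is larger than any step measured earlier, so a single methyl can matter more here than the wider swaps of the first three compounds did. The step of a 1.7-fold higher number from compound 2 to compound 4 (0.24 log units; within the scatter) lies within the scatter, so compound 2 and compound 4 cannot be told apart, although their groups differ in size and in the amine they carry.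

On these data alone, whether the methyl effect holds for an ethyl on the amine nitrogen, or for the same azetidine group with an unsubstituted amine, remains open. Nothing shown here accounts for any of these steps.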